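The source may report more compounds than this note shows. Statements on the series, on what has been measured and on what is new or still open speak of the compounds shown alone.

Three compounds share one core and differ only in a single group sitting on an aromatic carbon. Compound 1 `COC(=O)c1ccc(NC2=CC(=O)c3ncncc3C2=O)cc1` carries a methoxycarbonyl there, and in a functional assay on MIA PaCa-2 cells (Homo sapiens) for cytotoxicity, read by MTT assay, with a stated time of 72 h (a lower number here means a stronger inhibitor, a higher number a weaker inhibitor), compound 1 gives 2200 nM. Compound 2 `Nc1ccc(-c2ccc(NC3=CC(=O)c4ncncc4C3=O)cc2)cc1` carries a 4-aminophenyl instead, and compound 2 gives 2500 nM. Compound 3 `CCc1ccc(-c2ccc(NC3=CC(=O)c4ncncc4C3=O)cc2)cc1` carries a 4-ethylphenyl, and compound 3 gives 2000 nM, the lowest of the three numbers, although its gaps to the other two lie within the scatter. The measured steps reaching it were small: a 1.1-fold lower number from compound 1 to compound 3 (0.04 log units; within the scatter) and a 1.3-fold lower number from compound 2 to compound 3 (0.10 log units; within the scatter). Compound 4 `NS(=O)(=O)c1ccc(NC2=CC(=O)c3ncncc3C2=O)cc1` has not yet been measured; it differs from compound 3 by sulfamoyl in place of 4-ethylphenyl on an aromatic carbon. Among the compounds with values here, no measured step brings in a sulfamoyl. Still, the three steps of a 1.1-fold higher number from compound 1 to compound 2 (0.06 log units; within the scatter), a 1.1-fold lower number from compound 1 to compound 3 (0.04 log units; within the scatter) and a 1.3-fold lower number from compound 2 to compound 3 (0.10 log units; within the scatter) show that swapping the group at this position among three unlike choices left the number within the scatter, so a step of a 1.3-fold higher number from compound 3 to compound 4 (0.10 log units; within the scatter) is expected, no larger than the scatter. Compound 4 is therefore estimated at 2500 nM, with a range from 1000 nM to 6500 nM.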

Compound 4, half-maximal inhibitory concentration: > 10000 nM
Compound 4 was reported as a limit (the forecaster's own chance of this, stated with the estimate: 5%); middle value at least 4.0-fold (0.60 log units) away from the limit.
By their numbers in this assay, from the lowest: compounds 3, 1 and 2 (each within the scatter of the next). At a limit, above all of these: compound 4.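

Within the data shown here, the group at this position is not as free to change as the earlier compounds suggested: methoxycarbonyl, 4-aminophenyl and 4-ethylphenyl gave numbers within the scatter of one another, yet sulfamoyl gives an at least 5.0-fold higher number from compound 3 to compound 4 (0.69 log units; beyond the scatter) and an at least 4.0-fold higher number from compound 2 to compound 4 (0.60 log units; beyond the scatter) and an at least 4.5-fold higher number from compound 1 to compound 4 (0.65 log units; beyond the scatter). Compound 1 also lacks the six-membered aromatic ring of 4-ethylphenyl and stays within the scatter of compound 3, so losing that ring does not alone go with the jump. Compound 4 is reported only as a limit, so these steps give minimum sizes: the limit of > 10000 nM in this assay, at which 1 of the 4 values shown sits.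

Going by these compounds, what remains open is which part of sulfamoyl goes with the loss of activity. A methylsulfonyl group, which keeps the sulfur and both oxygens but drops the nitrogen, or a carboxylic acid at this position would help separate these parts.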